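The source may hold more compounds than are shown below. What is called first, only, known or untested is meant among the compounds shown, and "the series" means these compounds.

Compound 1, `CCC(C)N(c1ccnc(Nc2ccc(C#N)cc2)n1)c1c(F)cc(-c2ccc(C#N)cc2)cc1F`, gives 217000 nM in an ADME assay on MT4 cells (Homo sapiens) for cytotoxicity, read by MTT assay, with a stated time of 5 days; a lower number here means that less compound is tolerated, a higher number that more compound is tolerated.
Compound 2, `N#Cc1ccc(Nc2nccc(N(c3c(F)cc(-c4ccc(C#N)cc4)cc3F)C3CCCC3)n2)cc1`, gives 232000 nM in this assay.

Of the two numbers, compound 2 has the higher one, but a 1.1-fold higher number from compound 1 to compound 2 (0.03 log units; within the scatter) is within the scatter, so the two compounds are indistinguishable here. Compound 3, `N#Cc1ccc(Nc2nccc(N(CC(O)CO)c3c(F)cc(-c4ccc(C#N)cc4)cc3F)n2)cc1`, differs from compound 2 by 2,3-dihydroxypropyl in place of cyclopentyl on a nitrogen on an aromatic ring. Among the measured compounds shown here, the one measured step, a 1.1-fold higher number from compound 1 to compound 2 (0.03 log units; within the scatter), also swaps the group on that nitrogen and stayed within the scatter, yet no step tests a hydroxyl-bearing chain. Compound 3 is therefore expected to show no step beyond the scatter in this assay, estimated as a 1.1-fold higher number from compound 2 to compound 3 (0.03 log units; within the scatter). The estimate for compound 3 is 250000 nM, with a range of 120000 nM to 500000 nM.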

Compound 3, half-maximal cytotoxic concentration: 19500 nM
Compound 3: middle estimate off by 13-fold (1.11 log units), on the high side, outside the stated range (below it).
By their numbers in this assay, from the lowest: compound 3; then compounds 1 and 2 (each within the scatter of the next).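

Changing the group on this nitrogen on an aromatic ring is not always without effect in this assay: sec-butyl and cyclopentyl could not be told apart, but 2,3-dihydroxypropyl gives a clear drop against both (a 12-fold lower number from compound 2 to compound 3 (1.08 log units; beyond the scatter); an 11-fold lower number from compound 1 to compound 3 (1.05 log units; beyond the scatter)). Losing the ring alone does not account for the drop, since sec-butyl also has no ring, and the entering group differs from both in carrying oxygen. Nothing available explains this result.

On these data alone, it remains open whether a single hydroxyl would produce the same drop. An amine or a carboxylic acid on this nitrogen is also untested here.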